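Trifluoromethyl for fluoro at the Limit of Detection

The compounds below may be only part of what the source reports. "The series", "measured", "known", "first", "only" and "open" are said of these compounds alone.

Measured compounds in an assay on HEK293 cells for inhibition of Ataxin-2 (Mus musculus), read by fluorescence and Amplex Red; a higher number here means a weaker inhibitor, a lower number a stronger inhibitor:
Compound 1 `NS(=O)(=O)c1ccc(COc2ccc(CNC(=O)[C@@H]3CCC(=O)N3Cc3ccc(C(F)(F)F)cc3)cc2)cc1`: compound 1 gives > 5000 nM
Compound 2 `O=C(O)c1ccc(COc2ccc(CNC(=O)[C@@H]3CCC(=O)N3Cc3ccc(Br)cc3)cc2)cc1`: compound 2 gives > 5000 nM
Compound 3 `O=C(O)c1ccc(COc2ccc(CNC(=O)[C@@H]3CCC(=O)N3Cc3ccc(F)cc3)cc2)cc1`: compound 3 gives > 5000 nM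

Compound 3 stands at a limit of this assay rather than at a number, and the same holds for compound 1 and for compound 2. For the measured compounds named here, the one step among the measured compounds, a step that the two limits leave unreadable from compound 2 to compound 3, therefore cannot be read in size, because of the limit of > 5000 nM in this assay, at which 3 of the 3 values shown sit.

Compound 4 `O=C(O)c1ccc(COc2ccc(CNC(=O)[C@@H]3CCC(=O)N3Cc3ccc(C(F)(F)F)cc3)cc2)cc1` differs from compound 3 in a single place: trifluoromethyl in place of fluoro on an aromatic carbon. The benzyl group on the shared core of compound 3 thus carries a trifluoromethyl instead of a fluoro, on an aromatic carbon of a six-membered aromatic ring of carbon only.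

Going by the values given here, no measured step bears directly on this change. Compound 1 already carries the trifluoromethyl group and sits at a limit, and the fluoro and bromo analogues, compound 3 and compound 2, sit at the same limit, so the step in this assay is expected to stay within the scatter or to remain unreadable. Compound 4 is therefore expected to give about 9000 nM, in the range from 3000 nM to 40000 nM, with the step that the limit leaves unreadable from compound 3 to compound 4 expected to be small and most likely hidden again at the limit.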

Compound 4, half-maximal inhibitory concentration: > 5000 nM
Compound 4 gave a limit, no number; the forecaster's own chance of this, stated with the estimate: 85%; the middle value does not contradict the limit.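

In this assay compound 4 gives > 5000 nM, which is a limit of the assay and not a number. The steps joining compound 4 to compound 1, compound 2 and compound 3 cannot be read in size, because all four compounds share one limit: the limit of > 5000 nM in this assay, at which 4 of the 4 values shown sit. The compounds shown leave open how strongly any of them inhibits, and whether swapping these groups changes that at all.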